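A few compounds are considered here, and "the series" means these few. Any claim that something is new, unique, unknown or untested is made for them only; others in the source may bear on it.

In a functional assay on DU-145 cells (Homo sapiens) for cytotoxicity, read by MTT assay, with a stated time of 48 h (on this read-out higher numbers stand for weaker inhibition and lower numbers for stronger inhibition), compound 1 `COc1cc(OC)c(/C=C/C(=O)/C=C/c2cc3ccccc3nc2Cl)c(OC)c1` gives > 10000 nM as a limit, not a number. Compound 2 `COc1ccc(/C=C/C(=O)/C=C/c2cc3ccccc3nc2Oc2ccc(Br)cc2)cc1` gives > 10000 nM and this is also a limit. Going by these compounds, compound 3 `COc1ccc(/C=C/C(=O)/C=C/c2cc3ccccc3nc2Oc2ccc(Br)cc2)cc1OC` gives > 10000 nM and this too is only a limit, so its exact place is unknown. For the measured compounds named here, the one measured step is a step that the two limits leave unreadable from compound 2 to compound 3 and it adds methoxy in place of hydrogen on an aromatic carbon. Compound 4 `COc1cc(OC)c(/C=C/C(=O)/C=C/c2cc3ccccc3nc2Oc2ccc(Br)cc2)c(OC)c1` differs from compound 3 by 2,4,6-trimethoxyphenyl in place of 3,4-dimethoxyphenyl on a double-bonded chain carbon bound to a double-bonded chain carbon with 2,4,6-trimethoxyphenyl in place of 3,4-dimethoxyphenyl. Going by the values given here, no measured step gives a size to carry over, so no change beyond the scatter is expected, in either direction, because of the limit of > 10000 nM in this assay, at which 3 of the 3 values shown sit, and nothing stronger. The expected step is a step that the limit leaves unreadable from compound 3 to compound 4 and it should not be read as real. For compound 4 the estimated value is 14000 nM with an expected range from 5000 nM to 30000 nM and a report as a limit is likely.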

Compound 4, half-maximal inhibitory concentration: > 10000 nM
Compound 4 gave a limit, no number; the forecaster's own chance of this, stated with the estimate: 75%; the middle value is on the limit's open side.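

No step among compound 1, compound 2, compound 3 and compound 4 can be read, because all of them stand at the same limit: the limit of > 10000 nM in this assay, at which 4 of the 4 values shown sit.

The compounds shown leave open how strongly any of them acts in this assay, and whether any of these group changes alters that strength.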